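The source may hold more compounds than are shown below. What is called first, only, known or untested is meant among the compounds shown, and "the series" means these compounds.

Measured so far:
compound 1 `CCOc1cc(NC(=O)C2(NC(=O)c3ccc4c(C5CCCC5)c(-c5ncc(Cl)cn5)n(C)c4c3)CCC2)ccc1/C=C/C(=O)N[C@@H](CCCNC(=N)N)C(N)=O` — 0.467 h
compound 2 `CCOc1cc(NC(=O)C2(NC(=O)c3ccc4c(C5CCCC5)c(-c5ncc(Cl)cn5)n(C)c4c3)CCC2)ccc1/C=C/C(=O)OCOP(=O)(O)O` — 1.3 h
compound 3 `CCOc1cc(NC(=O)C2(NC(=O)c3ccc4c(C5CCCC5)c(-c5ncc(Cl)cn5)n(C)c4c3)CCC2)ccc1/C=C/C(=O)OCC(Cl)(Cl)Cl` — 1.75 h

In an ADME assay on stomach for pharmacokinetics, in simulated gastric fluid (a higher number here means that the compound lasts longer, a lower number that the compound disappears faster), compound 3 gives the highest of the three numbers. The gap to compound 1 is clear, a 3.7-fold higher number from compound 1 to compound 3 (0.57 log units; beyond the scatter), whereas the gap to compound 2, a 1.3-fold higher number from compound 2 to compound 3 (0.13 log units; within the scatter), is within the scatter, so compounds 2 and 3 cannot be told apart on these numbers.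

Compound 4 `CCOc1cc(NC(=O)C2(NC(=O)c3ccc4c(C5CCCC5)c(-c5ncc(Cl)cn5)n(C)c4c3)CCC2)ccc1/C=C/C(=O)OCc1ccccc1` differs from compound 3 by phenyl in place of trichloromethyl on a saturated chain carbon bound to an oxygen next to a carbonyl group. Among the measured compounds shown here, the one measured step at this same place, a 1.3-fold higher number from compound 2 to compound 3 (0.13 log units; within the scatter), stayed within the scatter. The other two steps, a 2.8-fold higher number from compound 1 to compound 2 (0.44 log units; beyond the scatter) and a 3.7-fold higher number from compound 1 to compound 3 (0.57 log units; beyond the scatter), exchanged the whole group on the carbonyl carbon and are only loosely comparable. Among the three measured compounds only the exchange on the carbonyl carbon itself moved the number beyond the scatter; the exchange one bond further out did not.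

Compound 4 is therefore expected to stay close to compound 3, with a step of a 1.1-fold lower number from compound 3 to compound 4 (0.04 log units; within the scatter) that is not expected to exceed the scatter. The estimate for compound 4 in this assay is 1.6 h, with a range from 0.8 h to 3.2 h.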

Compound 4, half-life: 1.83 h
Estimate against measurement, compound 4: 1.1-fold (0.06 log units) below; the measured number falls inside the stated range.
By their numbers in this assay, from the lowest: compound 1; then compounds 2, 3 and 4 (each within the scatter of the next).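

In this assay, a 1.0-fold higher number from compound 3 to compound 4 (0.02 log units; within the scatter) shows that this saturated chain carbon tolerates an aromatic ring of carbon as well as trichloromethyl, and a 1.4-fold higher number from compound 2 to compound 4 (0.15 log units; within the scatter) likewise stays within the scatter, so three quite different groups at this place give numbers that cannot be told apart. The only separation among the four compounds remains the exchange on the carbonyl carbon, now seen again in a 3.9-fold higher number from compound 1 to compound 4 (0.59 log units; beyond the scatter), so compound 1 alone stands apart from the others. No measurement at hand accounts for either observation.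

The compounds shown leave open where a free carboxylic acid or a primary amine on the carbonyl carbon would fall. They also leave open whether a longer chain in place of phenyl would stay within the scatter of compound 4.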